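The compounds below may be only part of what the source reports. "The series", "measured", "known", "first", "only" and "open" are said of these compounds alone.

The study concerns a small set of sulfonamides built on a shared core. In a functional assay on the whole organism (strain STD-dd) with Mus musculus as the target, in the maximal electroshock model, with a stated time of 2 h (on this read-out lower numbers stand for an effect already at smaller amounts and higher numbers for an effect only at larger amounts of compound), compound 1 `CC(C)NS(=O)(=O)Cc1noc2ccccc12` gives 56 mg/kg, and in this assay compound 2 `CNS(=O)(=O)Cc1noc2ccc(F)cc12` gives 35 mg/kg. Compound 2 stands beside compound 1 within the scatter of repeated measurements, so the two cannot be told apart on these numbers. Among the measured compounds shown here, compound 1 and compound 2 differ in more than one place, and no single step between them can be read.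

Compound 3 `CC(C)NS(=O)(=O)Cc1noc2ccc(F)cc12` has not yet been measured in this assay. It differs from compound 2 by isopropyl in place of methyl on a sulfonamide nitrogen. For the measured compounds named here, no measured pair shows this change on its own, so the size of its step is not known from the data; a step of no more than the scatter, in either direction, seems most likely, since compound 1 gives 56 mg/kg and compound 2 gives 35 mg/kg while differing in two places at once. Compound 3 is therefore expected to give about 45 mg/kg, within a range from 20 mg/kg to 100 mg/kg. The step this estimate means, a 1.3-fold higher number from compound 2 to compound 3 (0.11 log units; within the scatter), is expected to stay within the scatter.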

Compound 3, dose for half-maximal effect: 38 mg/kg
The estimate for compound 3 lay 1.2-fold (0.07 log units) above the measured number, within the range that was stated.
By their numbers in this assay, from the lowest: compounds 2, 3 and 1 (each within the scatter of the next).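

In this assay, among the compounds shown here, the change of methyl to isopropyl on a sulfonamide nitrogen, which no earlier pair showed alone, can now be read as a 1.1-fold higher number from compound 2 to compound 3 (0.04 log units; within the scatter) and leaves compound 2 and compound 3 indistinguishable on these numbers. Compound 3 also isolates the other difference between the earlier compounds: fluoro in place of hydrogen on an aromatic carbon reads as a 1.5-fold lower number from compound 1 to compound 3 (0.17 log units; within the scatter) and so does not separate compound 1 from compound 3 either, which means that neither single change shown here has a step beyond the scatter. Nothing at hand bears on what lies behind these two results. 

On the sulfonamide nitrogen, only methyl and isopropyl appear, so the compounds shown leave open whether a cyclohexyl ring, a longer chain ending in an amine or a carboxylic acid, or a bare amino group would keep the number within the same scatter. On the aromatic carbon, fluoro is the only replacement for hydrogen, which leaves chloro, methoxy and nitrile there unanswered.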